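Butyl in Place of Propanoyl on a Sigma Ligand

This account rests on a few compounds, and the source may have more. Where it says the series, first, only, none or still open, it means among the compounds named here.

compound 1 `CCC(=O)c1ccc2c(c1)sc(=O)n2CCCCN1CCCCCC1`: 10.3 nM
compound 2 `CCC(=O)c1ccc2c(c1)sc(=O)n2CCCCCCN1CCCCCC1`: 10.4 nM

In an assay on cell membranes for displacement of a labelled ligand from Sigma non-opioid intracellular receptor 1 (Rattus norvegicus) (a higher number here means a weaker inhibitor, a lower number a stronger inhibitor), compound 1 gives 10.3 nM, and compound 2 gives 10.4 nM. The step of a 1.0-fold higher number from compound 1 to compound 2 (0.00 log units; within the scatter) stays within the scatter, so compound 2 stands level with compound 1 on these two numbers. Compound 3 `CCCCc1ccc2c(c1)sc(=O)n2CCCCCCN1CCCCCC1` is not yet measured; it differs from compound 2 by butyl in place of propanoyl on an aromatic carbon. Going by the values given here, no measured step bears on this change; the one step in hand concerns the chain, not the ring. The estimate for compound 3 is therefore 8 nM, between 2 nM and 30 nM, meaning an expected step of a 1.3-fold lower number from compound 2 to compound 3 (0.11 log units; within the scatter).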

Compound 3, inhibition constant: 12 nM
Compound 3: the middle estimate sits 1.5-fold (0.18 log units) below what was measured; low and high end bracket the measured number.
By their numbers in this assay, from the lowest: compounds 1, 2 and 3 (each within the scatter of the next).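

In this assay, going by these compounds alone, butyl in place of propanoyl on this aromatic carbon gives a 1.2-fold higher number from compound 2 to compound 3 (0.06 log units; within the scatter), so the earlier chain step is now joined by a first step at the ring. The hydrogen-bond acceptor that leaves with propanoyl is not required to keep the number within the scatter of compound 2. Nothing measured explains why the two groups read alike. As far as these compounds go, whether an amine or a carboxylic acid at this carbon would also hold the number remains open. So does whether butyl would read the same on the shorter chain of compound 1.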